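A few compounds are considered here, and "the series" means these few. Any claim that something is new, unique, unknown or untested is made for them only; others in the source may bear on it.

Of the compounds shown here, three with a shared core have been tested in a functional assay on HGC-27 cells (Homo sapiens) for cytotoxicity, read by MTT assay, with a stated time of 72 h; a lower number here means a stronger inhibitor, a higher number a weaker inhibitor: compound 1, `FC(F)(F)c1ccc(CSc2nc(N3CCCCC3)c3ccccc3n2)cc1`, compound 2, `Fc1ccc(Nc2nc(SCc3ccc(C(F)(F)F)cc3)nc3ccccc23)cc1`, and compound 3, `O=[N+]([O-])c1ccc(Nc2nc(SCc3ccc(C(F)(F)F)cc3)nc3ccccc23)cc1`. Compound 1 gives only a limit of the assay, > 50000 nM. Compound 2 gives 19500 nM, and compound 3 gives 16600 nM. Among the two compounds with a proper number, compound 3 holds the lower one, but the gap to compound 2 is within the scatter: a 1.2-fold lower number from compound 2 to compound 3 (0.07 log units; within the scatter). The larger changes are those from the compound with the limit: an at least 2.5-fold lower number from compound 1 to compound 2 (0.40 log units; beyond the scatter) and an at least 3.0-fold lower number from compound 1 to compound 3 (0.47 log units; beyond the scatter).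

Compound 4, `COc1ccc(Nc2nc(SCc3ccc(C(F)(F)F)cc3)nc3ccccc23)c(OC)c1`, is not yet measured. It differs from compound 3 in one place: 2,4-dimethoxyphenyl in place of 4-nitrophenyl on a nitrogen on an aromatic ring. The measured step that bears most directly on this change is the swap of the group on the phenylamino ring from compound 2 to compound 3, which left the number essentially unchanged. A similar swap, to two methoxy groups, is therefore expected to give no step beyond the scatter in this assay, so a 1.0-fold lower number from compound 3 to compound 4 (0.02 log units; within the scatter) is the estimated change. Compound 4 is expected to give about 16000 nM, most likely between 6000 nM and 45000 nM.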

Compound 4, half-maximal inhibitory concentration: > 50000 nM
Compound 4 was reported as a limit; the forecaster's own chance of this, stated with the estimate: 12%; middle value at least 3.1-fold (0.49 log units) away from the limit.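

In this assay, the group on this nitrogen turns out to matter: 2,4-dimethoxyphenyl in place of 4-nitrophenyl gives an at least 3.0-fold higher number from compound 3 to compound 4 (0.47 log units; beyond the scatter), and in place of 4-fluorophenyl it gives an at least 2.5-fold higher number from compound 2 to compound 4 (0.40 log units; beyond the scatter). The earlier pair, compound 2 and compound 3, could not be told apart, so they gave no sign that a swap on this phenyl ring could cost activity; compound 4 shows that keeping the amino link and the phenyl ring is not enough to hold the number. As far as these compounds go, compound 4 gives only a limit of the assay, so the full size of both steps stays unknown.

From the compounds shown here alone, the step between compound 1 and compound 4 cannot be read, because both values are limits: the limit of > 50000 nM in this assay, at which 2 of the 4 values shown sit. Still open is whether two methoxy groups are needed for this loss, or whether a single methoxy group, or an amine on the same ring, would also bring it.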